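Swapping an aryl group for furan-2-yl

The source may hold more compounds than are shown below. What is called first, only, known or untested is meant among the compounds shown, and "the series" means these compounds.

- compound 1 `CCOC(=O)c1cnn(-c2nc(-c3ccc(OC)cc3)c(C#N)c(=O)n2C)c1N` gives 68 ug/mL
- compound 2 `CCOC(=O)c1cnn(-c2nc(-c3ccc(N(C)C)cc3)c(C#N)c(=O)n2C)c1N` gives 111 ug/mL

In a functional assay on microsomes for inhibition, with a stated time of 1 h (on this read-out higher numbers stand for weaker inhibition and lower numbers for stronger inhibition), compound 2 stands at 111 ug/mL and cannot be told apart from compound 1 at 68 ug/mL in practice. The next compound is compound 3 `CCOC(=O)c1cnn(-c2nc(-c3ccco3)c(C#N)c(=O)n2C)c1N`, which keeps the shared core but changes the group ortho to a cyano group: furan-2-yl in place of 4-(dimethylamino)phenyl on an aromatic carbon is the whole difference. Within the data shown here, the only measured step is a 1.6-fold higher number from compound 1 to compound 2 (0.21 log units; within the scatter) and it swaps dimethylamino for methoxy. That step leaves the rest of the 4-(dimethylamino)phenyl group in place, so it bears only loosely on replacing the whole group. Among the measured compounds shown here, no measured compound carries furan-2-yl, and the data give no direction. The expected change in this assay is a 1.4-fold lower number from compound 2 to compound 3 (0.14 log units; within the scatter) as a best guess, with nothing expected beyond the scatter. For compound 3 the estimated value is 80 ug/mL with an expected range from 30 ug/mL to 210 ug/mL (an estimate, not a measurement).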

Compound 3, half-maximal inhibitory concentration: 116 ug/mL
Compound 3: the middle estimate sits 1.5-fold (0.16 log units) below what was measured, and the stated range covers the measured number.
By their numbers in this assay, from the lowest: compounds 1, 2 and 3 (each within the scatter of the next).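

In this assay the whole aryl group can be exchanged: furan-2-yl in place of 4-(dimethylamino)phenyl gives a 1.0-fold higher number from compound 2 to compound 3 (0.02 log units; within the scatter) and furan-2-yl in place of 4-methoxyphenyl gives a 1.7-fold higher number from compound 1 to compound 3 (0.23 log units; within the scatter) and neither swap separates the compounds. The earlier pair differed only in a small group on the same phenyl ring, whereas here the group ortho to a cyano group goes from 9 heavy atoms to 5 and becomes a five-membered aromatic ring with 1 hetero atom, and compounds 1, 2 and 3 still cannot be told apart. Nothing at hand explains why these numbers stay so close.

From the compounds shown here alone, all three groups at this position are aromatic rings, so it stays open how the read-out would respond to an amine, a carboxylic acid or a plain alkyl chain there. Also open, going by these compounds, is whether any group at this position can move the number beyond the scatter.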